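Adding a Bromo Group to Compound 1

This account rests on a few compounds, and the source may have more. Where it says the series, first, only, none or still open, it means among the compounds named here.

Among the measured compounds shown here, in a functional assay on MCF7 cells (Homo sapiens) for inhibition, read by MTT assay, with a stated time of 48 h (a higher number here means a weaker inhibitor, a lower number a stronger inhibitor), compound 1 `c1ccc(-c2ccnc3c2c(-c2ccccc2)nn3-c2ccccc2)cc1` gives 28200 nM as the highest of the three numbers measured so far. Two compounds with a different core lie beyond the usual scatter below it: compound 2 `O=C(C=CNc1cc(-c2ccccc2)nn1-c1ccccc1)c1ccc(Cl)cc1` at 8070 nM and compound 3 `O=C(C=CNc1cc(-c2ccccc2)nn1-c1ccccc1)c1ccc(F)cc1` at 9180 nM on the same scale.

The next compound, compound 4 `Brc1ccc(-c2ccnc3c2c(-c2ccccc2)nn3-c2ccccc2)cc1`, keeps the core of compound 1 and alters one place. The change is bromo in place of hydrogen on an aromatic carbon and it amounts to bromo in place of hydrogen on an aromatic carbon, turning phenyl to 4-bromophenyl.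

For the measured compounds named here, only one measured step offers a guide: a 1.1-fold higher number from compound 2 to compound 3 (0.06 log units; within the scatter) when fluoro replaces chloro on an aromatic carbon. That step is small, but it swaps one halogen for another on a different core, so it cannot show directly what adding a halogen in place of hydrogen will do. Compound 2 and compound 3 also differ from compound 1 in much more than a halogen. The expected change is a 1.4-fold lower number from compound 1 to compound 4 (0.15 log units; within the scatter) as a modest estimated shift toward a lower number, not clearly beyond the scatter. For compound 4 the estimated value is 20000 nM with an expected range from 8000 nM to 50000 nM in this assay once it is measured.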

Compound 4, half-maximal inhibitory concentration: 13300 nM
Estimate against measurement, compound 4: 1.5-fold (0.18 log units) above; the range from low to high includes it.
By their numbers in this assay, from the lowest: compounds 2, 3 and 4 (each within the scatter of the next); then compound 1.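

Turning phenyl to 4-bromophenyl gives a 2.1-fold lower number from compound 1 to compound 4 (0.33 log units; beyond the scatter) in this assay. This step is modest, yet it shows that a single heavy atom entering in place of hydrogen on this six-membered aromatic ring can shift the reading on the core of compound 1 by more than ordinary repeat-to-repeat variation. The earlier halogen step could not show this, since it exchanged one halogen for another on a different core, whereas this is the first direct look at adding a halogen at this position, although no supporting measurement shown here explains the shift.

With only hydrogen and bromo shown at this position on this core, it remains open whether fluoro or chloro would have a similar effect, or whether an amine, a methoxy group or a carboxylic acid would move the number in the same direction or the opposite one. On these data alone, it is also open whether bromo would produce a comparable step elsewhere on the core, since one pair of compounds describes only this one position.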